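Acyl group change on the shared core: tolerance notes

The compounds below may be only part of what the source reports. "The series", "measured", "known", "first", "only" and "open" are said of these compounds alone.

Compound 1 `Cn1c(-c2ccccc2F)cnc1NC(=O)c1ccc(F)cc1`, compound 3 `Cc1ccc(-c2cnc(NC(=O)c3ccc(F)cc3)n2C)cc1` and compound 2 `COc1ccc(-c2cnc(NC(=O)C3CCOCC3)n2C)cc1` share one core and differ in the aryl group on the aromatic carbon and in the acyl group on the carbonyl carbon. In a toxicity assay on THP-1 cells (Homo sapiens) for inhibition (a lower number here means that less compound is tolerated, a higher number that more compound is tolerated), compound 1 gives > 100000 nM, which is a limit of the assay rather than a number. Compound 3 gives 60000 nM in this assay. Compound 2 gives > 100000 nM in this assay, again a limit, so compound 2 stands at the limit of > 100000 nM in this assay, at which 2 of the 3 values shown sit. For the measured compounds named here, the only measured step, an at least 1.6-fold lower number from compound 1 to compound 3 (0.22 log units; that floor lies within the scatter), concerns the aryl group on the aromatic carbon and lies within the scatter.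

Compound 4 `COc1ccc(-c2cnc(NC(=O)c3ccccc3C#N)n2C)cc1` is not yet measured. It differs from compound 2 in 2-cyanophenyl in place of oxan-4-yl on a carbonyl carbon. Going by the values given here, no measured step touches the carbonyl carbon, so none bears directly on this change. Compound 3, which carries an aromatic acyl group, sits at 60000 nM in this assay. Compound 1 also carries an aromatic acyl group, and its result in this assay is only a limit. Compound 4 is therefore expected to stay near the limit in this assay, estimated at 90000 nM with a range from 30000 nM to 300000 nM. The expected step of an at least 1.1-fold lower number from compound 2 to compound 4 (0.04 log units; that floor lies within the scatter) is estimated to remain within the scatter, with a fair chance that only a limit is reported again.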

Compound 4, half-maximal cytotoxic concentration: > 100000 nM
Compound 4: no number, only a limit; the forecaster's own chance of this, stated with the estimate: 60%; at least 1.1-fold (0.04 log units) between middle value and limit.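

In this assay compound 4 gives > 100000 nM, a limit of the assay and not a number. Compound 2 also stands at a limit, so no step can be read between compound 2 and compound 4, and the series stands as follows: the limit of > 100000 nM in this assay, at which 3 of the 4 values shown sit.

The compounds shown leave open whether 2-cyanophenyl in place of oxan-4-yl on a carbonyl carbon changes tolerance at all.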